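Fluoro scan on two phenyl-bearing cores, single-concentration inhibition

This account rests on a few compounds, and the source may have more. Where it says the series, first, only, none or still open, it means among the compounds named here.

Measured so far in an assay on isolated protein for inhibition of Rho-associated protein kinase 1 (Homo sapiens), tested at 30 uM; a lower number here means less inhibition, a higher number more inhibition at the concentration tested (going by the name of the read-out):
compound 1, `Clc1ncnc2c1ncn2Cc1ccccc1`, gives 3%
compound 2, `Fc1ccc(Cn2cnc3c(Cl)ncnc32)cc1`, gives 0%
compound 3, `Cn1c(-c2ccccc2)nc2c(Sc3ccccc3)ncnc21`, gives 1%

All three numbers sit close to the floor of this assay, and none of the gaps between them is beyond the scatter. Among the compounds with values here, compound 1 and compound 2 form the one matched pair with a counted step: the change is fluoro in place of hydrogen on an aromatic carbon, and it gives a number 3 percentage points lower from compound 1 to compound 2 (within the scatter). Compound 3 carries a different core; how its core differs from that of compound 1 is not broken down here, so its value is simply read on its own.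

Compound 4, `Cn1c(-c2ccccc2)nc2c(Sc3ccc(F)cc3)ncnc21`, has not yet been measured in this assay. It differs from compound 3 by fluoro in place of hydrogen on an aromatic carbon, which is the same change as that from compound 1 to compound 2, on the same kind of place, and it occurs twice across the set. Within the data shown here, the only precedent for this change on a measured pair is the step from compound 1 to compound 2, which stays within the scatter on a near-zero baseline.

On that basis the expected step from compound 3 to compound 4 in this assay is no change at the digits printed from compound 3 to compound 4 (within the scatter), resting on compound 3 giving 1% and on the earlier pair moving by a number 3 percentage points lower from compound 1 to compound 2 (within the scatter). Compound 4 is accordingly estimated at 1%, with a plausible range from 0% to 8%.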

Compound 4, a percentage reported as inhibition, at one concentration (the size of the read-out at that concentration, not a potency): 9%
Estimate against measurement, compound 4: 8 percentage points below, and the stated range ends below it.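

In this assay, fluoro in place of hydrogen on an aromatic carbon, here phenylsulfanyl to (4-fluorophenyl)sulfanyl, gives a number 8 percentage points higher from compound 3 to compound 4 (within the scatter). Set beside the earlier step, the change reads the same on the two cores: the same change on two cores in this assay, a number 3 percentage points lower (within the scatter) from compound 1 to compound 2 and a number 8 percentage points higher (within the scatter) from compound 3 to compound 4, 11 percentage points apart, within the scatter of two such steps What this shows is limited but usable: in the two matched pairs available, the change has produced no step that rises out of the scatter, and the opposite signs of the two steps carry no weight. It does not show that the change is neutral in general, as both pairs are read at a single concentration with small numbers throughout, so any real effect of the change smaller than the scatter would go unseen, and a compound with a clearly higher starting value might respond differently.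

The compounds shown leave open whether anything other than fluoro at this place, such as an amine or a carboxylic acid on the same aromatic carbon, would move the read-out beyond the scatter. They also leave open whether a longer chain in place of the methyl group on the core of compound 3 would do so, and how the fluoro change would behave on such a compound.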